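The source may report more compounds than this note shows. Statements on the series, on what has been measured and on what is new or still open speak of the compounds shown alone.

In an assay on CHO cells for displacement of a labelled ligand from adenosine receptor A1 (Homo sapiens), read by scintillation counting, with a stated time of 120 min, tested at 10 uM (a lower number here means less inhibition, a higher number more inhibition at the concentration tested (going by the name of the read-out)), compound 1, whose structure is `Nc1scc(CN2CCN(c3ccc(Cl)cc3F)CC2)c1C(=O)c1ccc(Cl)cc1`, gives 0%. Compound 2, with the structure `Nc1scc(CN2CCN(c3cc(F)cc(F)c3)CC2)c1C(=O)c1ccc(Cl)cc1`, gives 0% in this assay. Within the data shown here, the step from one to the other, no change at the digits printed from compound 1 to compound 2 (within the scatter), therefore shows nothing beyond the scatter, and on the numbers at hand compound 2 stands level with compound 1, the only other measured compound. The compound still to be measured is compound 3, whose structure is `Nc1scc(CN2CCN(c3c(F)cccc3F)CC2)c1C(=O)c1ccc(Cl)cc1`. It differs from compound 2 in one place: 2,6-difluorophenyl in place of 3,5-difluorophenyl on an amine nitrogen in a ring. Among the measured compounds shown here, the single measured step that bears on this change is the one from compound 1 to compound 2, where one fluorinated phenyl group on the same ring nitrogen was exchanged for another without any movement in this assay. From that step alone, compound 3 is expected to show no step beyond the scatter, so the estimated change a number 2 percentage points higher from compound 2 to compound 3 (within the scatter) is close to nothing. Compound 3 is therefore estimated to give 2% in this assay, with a range from -8% to 12%.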

Compound 3, a percentage reported as inhibition, at one concentration (the size of the read-out at that concentration, not a potency): 1%
Compound 3: the middle estimate sits 1 percentage points above what was measured, within the range that was stated.
By their numbers in this assay, from the lowest: compounds 1, 2 and 3 (each within the scatter of the next).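

Swapping 2,6-difluorophenyl for 3,5-difluorophenyl on the amine nitrogen in a ring keeps the same atoms and joins them differently, and in this assay this gives a number 1 percentage points higher from compound 2 to compound 3 (within the scatter). Among these compounds, the earlier step had exchanged one fluorinated phenyl for another with a different set of atoms, so this is the first sign that rearranging the same two fluorines on the phenyl group also leaves the read-out inside the scatter. The step of a number 1 percentage points higher from compound 1 to compound 3 (within the scatter) agrees with this, and the three groups tried at this position cannot be told apart in this read-out, while nothing at hand offers any explanation for that sameness.

The compounds shown leave open whether anything other than a halogenated phenyl on this ring nitrogen, such as a plain phenyl, a methoxyphenyl or a pyridine, would move the number at all. They also leave open whether replacing the 4-chlorophenyl ketone part of the shared core, or turning its free amine into an amide, would bring any inhibition beyond the scatter.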